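Removing a ring methyl from a piperazine sulfonamide antagonist

A few compounds are considered here, and "the series" means these few. Any claim that something is new, unique, unknown or untested is made for them only; others in the source may bear on it.

Compound 1: `CCCn1c(=O)[nH]c2nc(-c3ccc(S(=O)(=O)N4CCN(c5ccccc5Br)CC4)cc3)[nH]c2c1=O`, 0.137 nM
Compound 2: `CCCn1c(=O)[nH]c2nc(-c3ccc(S(=O)(=O)N4CCN(c5ccccc5)C(C)C4)cc3)[nH]c2c1=O`, 7.15 nM

Of the compounds shown here, two sharing one core have been measured in an assay on CHO cells for displacement of a labelled ligand from adenosine receptor A2b (Homo sapiens), read by scintillation counting, with a stated time of 75 min, in the presence of a further agent that is not named here; a lower number here means a stronger inhibitor, a higher number a weaker inhibitor. Compound 1 gives 0.137 nM, while compound 2 gives 7.15 nM. On these numbers compound 2 stands as the higher of the two, and its gap to compound 1 lies well beyond the usual scatter of the measurement. The two structures differ in more than one place, so nothing can be said of any single change between them.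

Compound 3 is `CCCn1c(=O)[nH]c2nc(-c3ccc(S(=O)(=O)N4CCN(c5ccccc5)CC4)cc3)[nH]c2c1=O`, not yet measured in this assay. Against compound 2 it differs in one place only: hydrogen in place of methyl on a saturated ring carbon

Among the measured compounds shown here, no measured pair in this set isolates that change. For the measured compounds named here, the one comparison available, between compound 1 and compound 2, runs in the direction of a lower number for the compound without the methyl, but it carries a second difference as well. Compound 3 is therefore expected to give a moderately lower number than compound 2, with the step of a 4.8-fold lower number from compound 2 to compound 3 (0.68 log units; beyond the scatter) judged likely to exceed the scatter but with wide uncertainty. The estimate for compound 3 in this assay is 1.5 nM, within a range of 0.3 nM to 8 nM.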

Compound 3, inhibition constant: 0.643 nM
The estimate for compound 3 lay 2.3-fold (0.37 log units) above the measured number, within the range that was stated.
By their numbers in this assay, from the lowest: compound 1; then compound 3; then compound 2.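

In this assay the saturated ring carbon proves sensitive: hydrogen in place of methyl there, with nothing else altered, gives an 11-fold lower number from compound 2 to compound 3 (1.05 log units; beyond the scatter) and is a large step, so this single methyl on the six-membered non-aromatic ring accounts for a real loss on its own. Compound 3 also isolates the second difference that the opening pair carried, since hydrogen in place of bromo on an aromatic carbon gives a 4.7-fold higher number from compound 1 to compound 3 (0.67 log units; beyond the scatter) and is a modest step, which means the bromo compound holds the lower number and the two changes are now seen separately, with the methyl step the larger in this set. The material at hand offers no independent measurement that accounts for either step.

The compounds shown leave open whether an ethyl or a hydroxyl group on that same saturated ring carbon would cost as much as methyl does, and whether a chloro or a methoxy group would serve in place of bromo on the aromatic carbon. They also leave open how the two changes would combine in one compound carrying both methyl and bromo.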